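The source may report more compounds than this note shows. Statements on the series, on what has been measured and on what is new or still open speak of the compounds shown alone.

Measured in a functional assay on HCT-116 cells (Homo sapiens) for cytotoxicity, read by MTT assay, with a stated time of 72 h; on this read-out lower numbers stand for stronger inhibition and higher numbers for weaker inhibition:
- compound 1 `CC(C)[S+]([O-])CCCCN=C=S` gives 3740 nM
- compound 2 `CC(C)[S+]([O-])CCCCCN=C=S` gives 3420 nM

Within the data shown here, compound 2 lies within the scatter of compound 1, the only other measured compound, so the pair shows one level and no order. Compound 3 `CC(C)[S+]([O-])CCCCCCN=C=S` is described by a group of 4 heavy atoms (2 carbon, 1 nitrogen, 1 sulfur; no ring) in place of a group of 3 heavy atoms (1 carbon, 1 nitrogen, 1 sulfur; no ring), on a saturated chain carbon, five bonds along the chain from a sulfur. Among the measured compounds shown here, one measured step bears on this: a 1.1-fold lower number from compound 1 to compound 2 (0.04 log units; within the scatter), the same kind of exchange, made on a saturated chain carbon four bonds along the chain from a sulfur instead of five. That step is small, and a single step gives no trend to extend. No change beyond the scatter is therefore expected in this assay. The estimated 1.1-fold lower number from compound 2 to compound 3 (0.06 log units; within the scatter) stays within the scatter. For compound 3 the expected value is 3000 nM, with an estimated range of 1500 nM to 6000 nM.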

Compound 3, half-maximal inhibitory concentration: 9460 nM
Estimate against measurement, compound 3: 3.2-fold (0.50 log units) below; the measured number lies above the stated range.
By their numbers in this assay, from the lowest: compounds 2 and 1 (each within the scatter of the next); then compound 3.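

In this assay, among these compounds, the exchange of a group of 4 heavy atoms for a group of 3 heavy atoms, on a saturated chain carbon, five bonds along the chain from a sulfur, gives a 2.8-fold higher number from compound 2 to compound 3 (0.44 log units; beyond the scatter), the first step beyond the scatter, towards weaker inhibition. The same kind of exchange four bonds along the chain from a sulfur gave a 1.1-fold lower number from compound 1 to compound 2 (0.04 log units; within the scatter), so across these three compounds the outcome of this exchange differs with its place. Nothing on hand accounts for this step.

From the compounds shown here alone, whether a longer chain would carry the number further up in this assay or leave it level stays open. A single step beyond the scatter also does not show how an amine or a carboxylic acid on the chain would read.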